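The source may report more compounds than this note shows. Statements on the series, on what has been measured and on what is new or still open speak of the compounds shown alone.

Compound 1 `CC1CCN(c2nc(C(F)(F)F)ccc2CNC(=O)C(C)c2ccc3c(c2)CCC3)CC1` gives 57.4 nM in an assay on CHO-K1 cells for antagonist activity at transient receptor potential cation channel subfamily V member 1 (Homo sapiens), read by FLIPR; a higher number here means a weaker inhibitor, a lower number a stronger inhibitor.
Compound 2 `CC1CCN(c2nc(C(F)(F)F)ccc2CNC(=O)C(C)c2ccc3c(c2)CCO3)CC1` gives 29.7 nM in this assay.
Compound 3 `CC(C(=O)NCc1cc(C(F)(F)F)nn1-c1ccc(Cl)cc1)c1ccc2c(c1)CCC2` gives 45 nM in this assay.

Compound 3 stands second highest of the three numbers; its nearest neighbour is compound 1 and its furthest is compound 2, and both gaps lie within the scatter, so none of the three measured compounds is separated from the others on this read-out. Going by the values given here, the only step measured within one core, a 1.9-fold lower number from compound 1 to compound 2 (0.29 log units; within the scatter), concerns the group on the saturated chain carbon bound to the carbonyl carbon and is itself within the scatter.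

Compound 4 `CC(C(=O)NCc1cc(C(F)(F)F)nn1-c1ccc(F)c(F)c1)c1ccc2c(c1)CCC2` has not yet been measured. It differs from compound 3 by 3,4-difluorophenyl in place of 4-chlorophenyl on an aromatic nitrogen. Among the compounds with values here, no measured step touches the aryl group on the aromatic nitrogen: compound 3 is the only compound of its core with a number, and the step from compound 1 to compound 2 sits at another place in another core, so it gives no guidance on direction. Nothing in the data points to a step beyond the scatter either way. The expectation is therefore that compound 4 stays close to compound 3, with a 1.1-fold higher number from compound 3 to compound 4 (0.05 log units; within the scatter) as the estimated step. Compound 4 is estimated at 50 nM in this assay, with an expected range from 18 nM to 140 nM.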

Compound 4, inhibition constant: 30.5 nM
Beside the measured number, compound 4's estimate is 1.6-fold (0.21 log units) above it, and the stated range covers the measured number.
By their numbers in this assay, from the lowest: compounds 2, 4, 3 and 1 (each within the scatter of the next).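

In this assay, the aryl group on the aromatic nitrogen now has its first measured step, a 1.5-fold lower number from compound 3 to compound 4 (0.17 log units; within the scatter), with 3,4-difluorophenyl in place of 4-chlorophenyl. This position of the shared core therefore takes this exchange of one halogenated phenyl group for another without a separation on this read-out, though that holds only for this single pair. No measurement at hand bears on the reason for this read-out at this position.

Still open, on these data alone, is whether any group on this aromatic nitrogen moves the number beyond the scatter: a phenyl group carrying no halogen, or one carrying a methoxy group or an amine, would test how far this tolerance extends. As far as these compounds go, it is also open whether the change of group on the saturated chain carbon in a 1.9-fold lower number from compound 1 to compound 2 (0.29 log units; within the scatter) would read the same way on the core of compound 3, where that group has only one measured form.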